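This account rests on a few compounds, and the source may have more. Where it says the series, first, only, none or still open, it means among the compounds named here.

In an ADME assay on HepG2 cells (Homo sapiens) for cytotoxicity, read by MTT assay, with a stated time of 72 h (on this read-out higher numbers stand for lower toxicity in this test and lower numbers for higher toxicity in this test), compound 1 `O=[N+]([O-])c1c(CS(=O)(=O)c2ccccc2)nc2c(C#Cc3ccc(F)cc3)cc(Cl)cn12` gives > 3900 nM as a limit of the assay and not as a number. Compound 2 `O=[N+]([O-])c1c(CS(=O)(=O)c2ccccc2)nc2c(C#Cc3ccccc3F)cc(Cl)cn12` gives > 3900 nM which is also a limit. Compound 3 `Nc1ccc(C#Cc2cc(Cl)cn3c([N+](=O)[O-])c(CS(=O)(=O)c4ccccc4)nc23)cc1` gives > 3900 nM which is a limit as well. Within the data shown here, the whole record so far is therefore the limit of > 3900 nM in this assay, at which 3 of the 3 values shown sit, and no measured compound has a true number that could place compound 1 more exactly.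

The next compound is compound 4 `CC(O)(C#Cc1cc(Cl)cn2c([N+](=O)[O-])c(CS(=O)(=O)c3ccccc3)nc12)c1ccccc1` with 1-hydroxy-1-phenylethyl in place of 4-fluorophenyl on a triple-bonded carbon and, cut one bond further out, this reads as 2-(4-fluorophenyl)ethynyl to 3-hydroxy-3-phenylbut-1-yn-1-yl.

The measured steps that bear on this change are a step that the two limits leave unreadable from compound 1 to compound 2 and a step that the two limits leave unreadable from compound 1 to compound 3 and a step that the two limits leave unreadable from compound 2 to compound 3 and none of them has a size that can be read. They offer no sign of a move toward higher toxicity, but they cannot show that none will occur. The estimated step is a step that the limit leaves unreadable from compound 1 to compound 4 and no clear shift toward higher toxicity is expected in this assay on this evidence. The expected value for compound 4 is 8000 nM with an estimated range from 3500 nM to 30000 nM and a report as a limit again would be no surprise.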

Compound 4, half-maximal cytotoxic concentration: 18800 nM
The estimate for compound 4 lay 2.4-fold (0.37 log units) below the measured number; the range from low to high includes it.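

No new step can be read in this assay: compound 1, compound 2 and compound 3 each give a limit and not a number, so their steps to compound 4 have no readable size. The compounds shown leave open how far the true values of those three compounds lie from that of compound 4, with the record resting largely on one limit: the limit of > 3900 nM in this assay, at which 3 of the 4 values shown sit.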